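The source may hold more compounds than are shown below. What is called first, only, known or untested is meant among the compounds shown, and "the series" means these compounds.

Measured so far in an ADME assay on NIH3T3 cells (Mus musculus) for antiproliferative activity, read by MTT assay, with a stated time of 48 h, in the presence of a further agent that is not named here; a higher number here means a weaker inhibitor, a lower number a stronger inhibitor:
compound 1, `O=C(Nc1ccc(-n2ccc3c(NC(=O)c4ccccc4)nccc32)cc1)Nc1ccc(Cl)c(Cl)c1`, gives 11500 nM
compound 2, `O=C(Nc1ccc(-n2ccc3c(NC(=O)c4ccccc4)nccc32)cc1)c1cccc(C(F)(F)F)c1`, gives 50 nM
compound 3, `O=C(Nc1ccc(-n2ccc3c(NC(=O)c4ccccc4)nccc32)cc1)c1ccc(Cl)c(C(F)(F)F)c1`, gives 5650 nM

Compound 2 has the lowest number of the three. The steps of a 230-fold lower number from compound 1 to compound 2 (2.36 log units; beyond the scatter) and a 110-fold higher number from compound 2 to compound 3 (2.05 log units; beyond the scatter) both set it well apart from the other two, whereas compound 1 and compound 3 lie close together, as a 2.0-fold lower number from compound 1 to compound 3 (0.31 log units; beyond the scatter) shows. Compound 4, `Cc1cn(-c2cc(C(=O)Nc3ccc(-n4ccc5c(NC(=O)c6ccccc6)nccc54)cc3)cc(C(F)(F)F)c2)cn1`, has not yet been measured. It differs from compound 2 by 4-methyl-1H-imidazol-1-yl in place of hydrogen on an aromatic carbon. Going by the values given here, the only measured step on that same ring is a 110-fold higher number from compound 2 to compound 3 (2.05 log units; beyond the scatter), a large one, but the chloro there sits at a different place from the entering ring, and no measured pair tells how a substituent at the new place behaves. On this basis one expects for compound 4 no step beyond the scatter, while keeping a wide range open. Compound 4 is therefore estimated at 40 nM, between 8 nM and 400 nM, an expected step of a 1.3-fold lower number from compound 2 to compound 4 (0.10 log units; within the scatter).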

Compound 4, half-maximal inhibitory concentration: 5570 nM
The estimate for compound 4 lay 140-fold (2.14 log units) below the measured number; the whole stated range lies below it.
By their numbers in this assay, from the lowest: compound 2; then compounds 4 and 3 (each within the scatter of the next); then compound 1.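

In this assay, the place meta to a trifluoromethyl group, which had no measured substituent until now, shows a 110-fold higher number from compound 2 to compound 4 (2.05 log units; beyond the scatter) when 4-methyl-1H-imidazol-1-yl replaces hydrogen there. Together with a 110-fold higher number from compound 2 to compound 3 (2.05 log units; beyond the scatter) on the same ring, this means that both substituents tried on this ring, at different places, give large steps away from compound 2, and no compound shown goes against that. Nothing measured here explains the step to compound 4.

As far as these compounds go, it remains open whether the step belongs to this particular ring or to any substituent at this place. A fluorine atom, a methyl group, an amine or an imidazole ring without its methyl at the same place would begin to separate these possibilities.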